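Adding a (dimethylamino)methyl group to an unsubstituted core

A few compounds are considered here, and "the series" means these few. Any claim that something is new, unique, unknown or untested is made for them only; others in the source may bear on it.

Measured compounds:
Compound 1, `Cc1ccc(/C=C/C(=O)Oc2ccc(/C=C3\CCCC(CN(C)C)C3=O)cc2)cc1`: 2430 nM
Compound 2, `CN(C)CC1CCC/C(=C\c2ccc(OC(=O)/C=C/c3ccc(F)cc3)cc2)C1=O`: 1840 nM
Compound 3, `O=C1CCCC/C1=C\c1ccc(OC(=O)c2ccc(Cl)cc2)cc1`: 3330 nM

All three numbers come from a functional assay on L1210 cells (Mus musculus); on this read-out lower numbers stand for stronger inhibition and higher numbers for weaker inhibition. Compound 3 gives the highest number of the three, yet its gaps to compound 1 and to compound 2 both lie within the usual scatter, so the three compounds cannot be told apart on these data.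

Within the data shown here, only one step between neighbours is known: a 1.3-fold lower number from compound 1 to compound 2 (0.12 log units; within the scatter). This step concerns a change on an aromatic carbon and says nothing about the change now at hand.

Compound 4, `CN(C)CC1CCC/C(=C\c2ccc(OC(=O)c3ccc(Cl)cc3)cc2)C1=O`, differs from compound 3 in one place: (dimethylamino)methyl in place of hydrogen on a saturated ring carbon. Among the measured compounds shown here, no measured pair isolates this change. Compound 1 and compound 2 carry the same group but differ from compound 3 in a second place as well, and their numbers in this assay sit within the scatter of the number for compound 3. On that basis no step beyond the scatter is expected in this assay, and the expected change is a 1.3-fold lower number from compound 3 to compound 4 (0.12 log units; within the scatter).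

The estimate for compound 4 in this assay is 2500 nM, with an expected range from 1200 nM to 5200 nM.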

Compound 4, half-maximal inhibitory concentration: 5610 nM
The estimate for compound 4 lay 2.2-fold (0.35 log units) below the measured number; measured number outside the range, above it.
By their numbers in this assay, from the lowest: compounds 2, 1, 3 and 4 (each within the scatter of the next, the first and the last beyond it).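

Compound 3 and compound 4 form the only pair shown that isolates (dimethylamino)methyl in place of hydrogen on a saturated ring carbon, and in this assay they give a 1.7-fold higher number from compound 3 to compound 4 (0.23 log units; within the scatter), so the group has no effect here that can be told from the usual scatter. The steps beyond the scatter appear at the carbonyl carbon instead: with the (dimethylamino)methyl group kept, 4-chlorophenyl in place of 2-(4-fluorophenyl)ethenyl gives a 3.0-fold higher number from compound 2 to compound 4 (0.48 log units; beyond the scatter), and 4-chlorophenyl in place of 2-(4-methylphenyl)ethenyl gives a 2.3-fold higher number from compound 1 to compound 4 (0.36 log units; beyond the scatter), both modest in size. Nothing available explains why these numbers move as they do.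

The compounds shown leave open whether the (dimethylamino)methyl group would also make no clear difference on a core carrying 2-(4-fluorophenyl)ethenyl or 2-(4-methylphenyl)ethenyl on the carbonyl carbon, since neither of those groups appears in a compound without it. They also leave open what a longer chain ending in the same amine, or a piperidine in place of the dimethylamino part, would do at this saturated ring carbon.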